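A few compounds are considered here, and "the series" means these few. Any claim that something is new, unique, unknown or untested is made for them only; others in the source may bear on it.

Measured so far:
Compound 1 `CC(=O)NCC#CCn1cncc1C`: 66 mg/kg
Compound 3 `COC(=O)NCC#CCn1cncc1C`: 66 mg/kg
Compound 2 `CC(=O)N(C)CC#CCN1CCCC1`: > 10 mg/kg, a limit of the assay, not a number

All values come from a functional assay on the whole organism for antagonist activity, with Mus musculus as the target; on this read-out higher numbers stand for an effect only at larger amounts of compound and lower numbers for an effect already at smaller amounts. The change from compound 1 to compound 3 is methoxy in place of methyl on a carbonyl carbon, and it gave no change at the digits printed from compound 1 to compound 3 (within the scatter). For compound 2 only the limit of > 10 mg/kg in this assay, at which 1 of the 3 values shown sits, is known. The core of compound 2 is not that of compound 1; the difference between the two cores is not broken down here.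

Compound 4 `COC(=O)N(C)CC#CCN1CCCC1` is still to be measured in this assay. It differs from compound 2 by methoxy in place of methyl on a carbonyl carbon, the same kind of change as that from compound 1 to compound 3, with the place described in the same words. For compound 4 the expected step is a step that the limit leaves unreadable from compound 2 to compound 4, because of no change at the digits printed from compound 1 to compound 3 (within the scatter). As compound 2 sits at the limit of > 10 mg/kg in this assay, at which 1 of the 3 values shown sits, the likeliest outcome for compound 4 is again a limit. Should a number be returned, compound 4 is expected near 30 mg/kg, within 10 mg/kg to 100 mg/kg.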

Compound 4, dose for half-maximal effect: > 10 mg/kg
Compound 4 was reported as a limit; the forecaster's own chance of this, stated with the estimate: 70%; the middle value is on the limit's open side.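

In this assay, for the compounds shown here, compound 2 and compound 4 both stand at a limit of the assay, not at a number, so no step from methyl to methoxy on the carbonyl carbon can be read between them: the limit of > 10 mg/kg in this assay, at which 2 of the 4 values shown sit. The compounds shown leave open where compound 2 and compound 4 would fall on a numeric scale, and whether they differ at all.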